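The compounds below may be only part of what the source reports. "The series", "measured", "known", "first", "only" and "open" are said of these compounds alone.

Compound 1 `O=C(/C=C/c1ccccc1)c1ccc(NC(=O)c2ccccc2)cc1`: 28000 nM
Compound 2 `CC(=O)Nc1ccc(C(=O)/C=C/c2cccc([N+](=O)[O-])c2)cc1`: 1800 nM
Compound 3 `O=C(/C=C/c1cccc([N+](=O)[O-])c1)c1ccc(NC(=O)c2cccs2)cc1`: 2500 nM

All three were tested in a functional assay on HCT-116 cells (Homo sapiens) for cytotoxicity, read by resazurin assay, with a stated time of 48 h; a lower number here means that less compound is needed, a higher number that more compound is needed for the effect. Among these numbers compound 3 stands second highest; its nearest neighbour is compound 2, and the one step that joins two measured compounds, a 1.4-fold higher number from compound 2 to compound 3 (0.14 log units; within the scatter), lies within the scatter. Within the data shown here, compound 1 gives by far the highest number, and no single step links it to compound 3.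

Compound 4 `O=C(/C=C/c1cccc([N+](=O)[O-])c1)c1ccc(NC(=O)c2ccccc2)cc1` has not yet been measured. Its difference from compound 3 is phenyl in place of thiophen-2-yl on a carbonyl carbon. Among the measured compounds shown here, no measured step exchanges one aromatic ring for another on this carbonyl carbon, so nothing bears on it directly. The nearest guide is a 1.4-fold higher number from compound 2 to compound 3 (0.14 log units; within the scatter), which shows that altering the group on this carbonyl carbon hardly moved the number. Compound 1 also carries the benzamido group, but differs from compound 4 elsewhere in the molecule, so its high value cannot be laid at the door of that group alone. The step expected from this change, a 1.2-fold higher number from compound 3 to compound 4 (0.08 log units; within the scatter), is therefore small and within the scatter. Compound 4 is estimated at 3000 nM, with a range from 1200 nM to 7500 nM.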

Compound 4, half-maximal effective concentration: 25000 nM
Estimate against measurement, compound 4: 8.3-fold (0.92 log units) below, outside the stated range (above it).
By their numbers in this assay, from the lowest: compounds 2 and 3 (each within the scatter of the next); then compounds 4 and 1 (each within the scatter of the next).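

In this assay the group on the carbonyl carbon, whose other neighbour is the amide-type nitrogen, turns out to matter after all: phenyl in place of thiophen-2-yl gives a 10-fold higher number from compound 3 to compound 4 (1.00 log units; beyond the scatter) and phenyl in place of methyl gives a 14-fold higher number from compound 2 to compound 4 (1.14 log units; beyond the scatter) while thiophen-2-yl in place of methyl gave only a 1.4-fold higher number from compound 2 to compound 3 (0.14 log units; within the scatter) so among these three groups phenyl alone stands apart. With benzamido in place, nitro in place of hydrogen on an aromatic carbon gives a 1.1-fold lower number from compound 1 to compound 4 (0.05 log units; within the scatter) so compound 1 and compound 4 cannot be told apart, and the nitro group shows no effect of its own in this pair. Nothing measured here explains why phenyl and thiophen-2-yl part so sharply on this carbonyl carbon.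

The compounds shown leave open whether a phenyl ring carrying an amine or a carboxylic acid, or a pyridine ring or a longer chain such as propyl, would stay near compound 4 or come back towards compound 3. They also leave open whether removing the nitro group would change the number when methyl or thiophen-2-yl sits on this carbonyl carbon.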